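Swapping the Indole on a Weakly Active Inhibitor

This account rests on a few compounds, and the source may have more. Where it says the series, first, only, none or still open, it means among the compounds named here.

Of the compounds shown here, three have been tested in a functional assay on K562 cells (Homo sapiens) for inhibition, read by trypan blue exclusion, with a stated time of 72 h; on this read-out higher numbers stand for weaker inhibition and lower numbers for stronger inhibition. Compound 1 `Cn1c(=O)c(S(=O)(=O)c2ccccc2)cc2cnc(Nc3ccc4cc[nH]c4c3)nc21` gives 10000 nM in this assay. Compound 2 `Cn1c(=O)c(S(=O)(=O)c2ccc(F)cc2F)cc2cnc(Nc3ccc4[nH]c(C(=O)O)cc4c3)nc21` gives 10000 nM, the same number as compound 1 at the digits shown. Compound 3 `O=c1[nH]c2nc(Nc3ccc4[nH]ccc4c3)ncc2cc1S(=O)(=O)c1ccc(F)cc1F` gives 15000 nM, which lies within the usual scatter of the number for compound 2, so no difference between them can be claimed. All three are weak inhibitors on this read-out.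

Compound 4 `Cn1c(=O)c(S(=O)(=O)c2ccc(F)cc2F)cc2cnc(Nc3ccc4c(c3)C(=O)C(=O)N4)nc21` has not yet been measured. It differs from compound 2 in one place: a group of 11 heavy atoms (8 carbon, 1 nitrogen, 2 oxygen; one five-membered non-aromatic ring with 1 hetero atom, one six-membered aromatic ring of carbon only) in place of a group of 12 heavy atoms (9 carbon, 1 nitrogen, 2 oxygen; one five-membered aromatic ring with 1 hetero atom, one six-membered aromatic ring of carbon only), on a nitrogen on an aromatic ring. No pair of measured compounds differs in just one place, so no step size is available to reason from. The three measured numbers sit close together even though the compounds carry different groups, so the change from compound 2 to compound 4 is expected to bring no shift beyond the scatter. Compound 4 is therefore estimated at 10000 nM in this assay, within a range of 5000 nM to 25000 nM. The step of no change at the digits printed from compound 2 to compound 4 (within the scatter) that this estimate means is expected to be flat.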

Compound 4, half-maximal inhibitory concentration: 30000 nM
Compound 4: the middle estimate sits 3.0-fold (0.48 log units) below what was measured, outside the stated range (above it).
By their numbers in this assay, from the lowest: compounds 1, 2, 3 and 4 (each within the scatter of the next, the first and the last beyond it).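

In this assay, putting the group with a five-membered non-aromatic ring in place of the 2-carboxy-1H-indol-5-yl group on this nitrogen gives a 3.0-fold higher number from compound 2 to compound 4 (0.48 log units; beyond the scatter), towards weaker inhibition. Within the data shown here, this shows that the group at this position can move the number, something the earlier compounds could not show, as none of them differed in just one place. No measurement at hand gives a reason for this shift.

Going by these compounds, the step replaces the aromatic five-membered ring and removes the carboxylic acid at the same time, so it remains open which of the two changes matters. Also open is whether another group in this place, such as a piperazine or a morpholine, would give stronger inhibition than any of these compounds.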